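Trifluoromethyl in Place of Fluoro: Expected Microsomal Half-Life

A few compounds are considered here, and "the series" means these few. Any claim that something is new, unique, unknown or untested is made for them only; others in the source may bear on it.

Compound 2 `CCC(/C=C1\OC(=O)NC1=O)(CC)c1ccc(-c2ccc3cccc(F)c3c2)[nH]c1=O` is the only one of the three measured compounds with a numeric result: in an ADME assay on microsomes from liver (Homo sapiens) for metabolic stability (on this read-out lower numbers stand for a shorter-lived compound and higher numbers for a longer-lived compound), compound 2 gives 0.948 h. Compound 1 `CCC(/C=C1\OC(=O)NC1=O)(CC)c1ccc(-c2ccc3cc(F)cc(F)c3c2)[nH]c1=O` sits at a limit of this assay, at > 3 h. Compound 3 `CC(C)/C(=C1/SC(=O)NC1=O)c1ccc(-c2ccc3cccc(F)c3c2)[nH]c1=O` likewise reaches a limit in this assay, at > 3 h. Within the data shown here, the single measured step, an at least 3.1-fold lower number from compound 1 to compound 2 (0.50 log units; beyond the scatter), rests on the limit of > 3 h in this assay, at which 2 of the 3 values shown sit, and so cannot be sized fully. Compound 4 `CCC(/C=C1\OC(=O)NC1=O)(CC)c1ccc(-c2ccc3cccc(C(F)(F)F)c3c2)[nH]c1=O` differs from compound 2 by trifluoromethyl in place of fluoro on an aromatic carbon. Among the measured compounds shown here, no measured step exchanges fluoro for trifluoromethyl; the only guide is that compound 1, with one more fluoro, reached the limit while compound 2 did not. A rise in this assay is therefore expected, of uncertain size, namely a 1.7-fold higher number from compound 2 to compound 4 (0.23 log units; within the scatter). For compound 4 the estimated value is 1.6 h, within 0.6 h to 3 h.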

Compound 4, half-life: 0.353 h
Compound 4: the middle estimate sits 4.5-fold (0.66 log units) above what was measured; the measured number lies below the stated range.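

In this assay, trifluoromethyl in place of fluoro on this aromatic carbon gives a 2.7-fold lower number from compound 2 to compound 4 (0.43 log units; beyond the scatter), so the read-out responds to the group at this position. More fluorine on the shared core therefore does not go with a higher number in every case: compound 1 carries its extra fluoro at another place. This step has a number at both ends, unlike the earlier one, which cannot be sized fully: the limit of > 3 h in this assay, at which 2 of the 4 values shown sit.

Going by these compounds, whether a methyl, a methoxy or a nitrile on this carbon would give a higher or lower number stays open. So does whether the same exchange would act alike on the core of compound 3.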